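Adding an Ethyl Group to a Carbamoyl Side Chain

The source may hold more compounds than are shown below. What is called first, only, known or untested is meant among the compounds shown, and "the series" means these compounds.

Compound 3 `CC1=C(C(N)=O)C(c2ccoc2)NC(=O)N1` sits at the low end of a small set. In an assay on membranes from HeLa cells for displacement of a labelled ligand from adenosine receptor A3 (Homo sapiens), read by scintillation counting, with a stated time of 180 min, tested at 1 uM (on this read-out lower numbers stand for less inhibition and higher numbers for more inhibition at the one concentration tested (going by the name of the read-out)), compound 3 gives 2%, level with compound 2 `CC(=O)C1=C(C)NC(=O)NC1c1ccoc1`, which gives 2%; the two share the lowest number of three, and there is no change at the digits printed from compound 2 to compound 3 (within the scatter). Compound 1 `CC1=C(C(=O)OCC(C)C)C(c2ccoc2)NC(=O)N1` stands higher with 16%, so that a number 14 percentage points lower from compound 1 to compound 3 (beyond the scatter) and a number 14 percentage points lower from compound 1 to compound 2 (beyond the scatter).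

Compound 4 `CCNC(=O)C1=C(C)NC(=O)NC1c1ccoc1` differs from compound 3 on its carbamoyl group: ethyl in place of hydrogen on an amide-type nitrogen, carbamoyl to ethylcarbamoyl. Going by the values given here, no measured step makes exactly this change. The nearest guides are the two steps into compound 3, where the larger isobutoxy group on the carbonyl carbon went with the higher number and methyl made no difference. A modest rise, likely within the scatter, is therefore expected: a number 6 percentage points higher from compound 3 to compound 4 (within the scatter). Compound 4 is thus estimated at 8%, within 0% to 20%.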

Compound 4, a percentage reported as inhibition, at one concentration (the size of the read-out at that concentration, not a potency): 1%
Beside the measured number, compound 4's estimate is 7 percentage points above it; measured number inside the range.
By their numbers in this assay, from the lowest: compounds 4, 2 and 3 (each within the scatter of the next); then compound 1.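

In this assay, ethyl on the amide-type nitrogen gives a number 1 percentage points lower from compound 3 to compound 4 (within the scatter) and also a number 1 percentage points lower from compound 2 to compound 4 (within the scatter) in the same sentence of small numbers, so ethylamino on the carbonyl carbon falls in with amino and methyl. Isobutoxy stays apart, with a number 15 percentage points lower from compound 1 to compound 4 (beyond the scatter) beyond what ethylamino reaches, so adding this chain on the nitrogen does not recover the number of compound 1. Nothing at hand explains this result.

Still open, on these data alone, is whether a longer chain or a phenyl ring on that nitrogen would raise the number. Open too, as far as these compounds go, is whether ethoxy on the carbonyl carbon would keep the number of compound 1.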